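The compounds below may be only part of what the source reports. "The series", "measured", "known", "first", "only" and "open" are said of these compounds alone.

In a functional assay on MCF7 cells (Homo sapiens) for cytotoxicity, read by MTT assay, with a stated time of 48 h (a lower number here means a stronger inhibitor, a higher number a weaker inhibitor), the evidence on this series is thin. Compound 1 `COc1ccc(-c2c[nH]c(=O)n2-c2cc(OC)c(OC)c(OC)c2)cc1` is recorded as "not determined" (no result reported), and compound 2 `COc1ccc(-c2cn(C(=O)Nc3cc(OC)c(OC)c(OC)c3)c(=O)n2-c2cc(OC)c(OC)c(OC)c2)cc1O` as "not determined" (no result reported). Compound 3 `COc1cc(-n2c(-c3ccccc3)cn(C(C)=O)c2=O)cc(OC)c1OC` gives > 50000 nM, which is a limit of the assay and not a number. For the measured compounds named here, the only reading available is thus (the limit of > 50000 nM in this assay, at which 1 of the 3 values shown sits). Compound 4 `COc1cc(-n2c(-c3ccc([N+](=O)[O-])cc3)cn(C(C)=O)c2=O)cc(OC)c1OC` differs from compound 3 in one place, with phenyl becoming 4-nitrophenyl: nitro in place of hydrogen on an aromatic carbon. Going by the values given here, no measured step between compounds is available as a guide, so only a small move toward stronger inhibition in this assay is expected, and it may not exceed the scatter. The expected change is an at least 1.1-fold lower number from compound 3 to compound 4 (0.04 log units; that floor lies within the scatter). The estimate for compound 4 is 45000 nM, with an expected range from 15000 nM to 100000 nM.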

Compound 4, half-maximal inhibitory concentration: > 50000 nM
Compound 4 gave a limit, no number; the forecaster's own chance of this, stated with the estimate: 55%; at least 1.1-fold (0.04 log units) between middle value and limit.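

In this assay, for the compounds shown here, compound 3 and compound 4 each give only a limit and no number, and no step between them can be read. From the compounds shown here alone, whether nitro in place of hydrogen changes inhibition at all remains open.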